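The source may hold more compounds than are shown below. What is called first, only, known or untested is meant among the compounds shown, and "the series" means these compounds.

Compound 2 `Cc1cc(NC(=O)Cn2nnc(-c3ccccc3)n2)n(C(C)C)n1` is the stronger of the two measured compounds: in an assay on HEK293 cells for activation of Kir3.1/Kir3.2 (Homo sapiens), read by thallium flux (on this read-out higher numbers stand for larger maximal responses and lower numbers for smaller maximal responses), compound 2 reaches 107%, and the gap to the next compound lies beyond the usual scatter. Compound 1 `Cc1cc(NC(=S)Cn2nnc(-c3ccccc3)n2)n(C2CCCCC2)n1` reaches 80% in this assay. Compound 3 `Cc1cc(NC(=O)Cn2nnc(-c3ccccc3)n2)n(C2CCS(=O)(=O)CC2)n1` is not yet measured; it differs from compound 2 by 1,1-dioxothian-4-yl in place of isopropyl on an aromatic nitrogen. Among the compounds with values here, no measured pair shows a change of this kind, so the expectation rests on compound 2 alone. The step from compound 2 to compound 3 is expected to be a number 9 percentage points lower from compound 2 to compound 3 (within the scatter), no larger than the scatter. Compound 3 is estimated at 98%, in a range from 75% to 120%.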

Compound 3, largest response reached (Emax), in percent of the reference or control that the assay uses: > 25%
Compound 3: only a limit was reported (the forecaster's own chance of this, stated with the estimate: 0%); the middle value lies beyond the limit too.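

In this assay, within the data shown here, compound 3 gives only a limit of > 25% and not a number, and no step from compound 2 to compound 3 can be read. The compounds shown leave open how far 1,1-dioxothian-4-yl in place of isopropyl changes the maximal response.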